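Hydroxyalkyl amine substituents in a coumarin series

The source may report more compounds than this note shows. Statements on the series, on what has been measured and on what is new or still open speak of the compounds shown alone.

Measured so far:
compound 1, `Cc1c(C)c2ccc(OCC3CCN(Cc4cccc(CO)c4)CC3)cc2oc1=O`, 76 nM
compound 2, `Cc1c(C)c2ccc(OCC3CCN(Cc4cccc(OCCCO)c4)CC3)cc2oc1=O`, 780 nM

Among the compounds with values here, in an assay for inhibition of Amine oxidase [flavin-containing] B (Homo sapiens), read by fluorescence, using microsomes, with a stated time of 30 min (on this read-out higher numbers stand for weaker inhibition and lower numbers for stronger inhibition), compound 2 gives the higher of the two numbers; compound 1 stands a long way below it, the only step recorded being a 10-fold higher number from compound 1 to compound 2 (1.01 log units; beyond the scatter). Compound 3, `Cc1c(C)c2ccc(OCC3CCN(CCCCO)CC3)cc2oc1=O`, is not yet measured. Relative to compound 2 the change is 3-hydroxypropyl in place of 3-(3-hydroxypropoxy)phenyl on a saturated chain carbon bound to an amine nitrogen in a ring. Within the data shown here, no measured step removes the aromatic ring from the amine substituent, so the one recorded step bears only loosely on this change: it shows that lengthening the hydroxyalkyl arm on the ring cost a large amount, but says nothing about the ring itself. The expectation is therefore tentative: a further move toward weaker inhibition, of moderate size, a 2.6-fold higher number from compound 2 to compound 3 (0.41 log units; beyond the scatter). Compound 3 is expected to give about 2000 nM in this assay, with a range from 500 nM to 8000 nM.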

Compound 3, half-maximal inhibitory concentration: 3600 nM
Compound 3: middle estimate off by 1.8-fold (0.26 log units), on the low side; measured number inside the range.
By their numbers in this assay, from the lowest: compound 1; then compound 2; then compound 3.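

Taking the aromatic ring out of the amine substituent moves this assay toward weaker inhibition in both available comparisons: a 4.6-fold higher number from compound 2 to compound 3 (0.66 log units; beyond the scatter) and a 47-fold higher number from compound 1 to compound 3 (1.68 log units; beyond the scatter) are both beyond the scatter. At this saturated chain carbon bound to an amine nitrogen in a ring, both compounds bearing a six-membered aromatic ring of carbon therefore give lower numbers than the ring-free compound 3, whichever hydroxyl-bearing arm the ring carries. Nothing measured here accounts for the loss.

The compounds shown leave open whether the terminal hydroxyl contributes at all. An unsubstituted phenyl, or an amine or a carboxylic acid in place of that hydroxyl, would separate its contribution from that of the ring.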